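The source may hold more compounds than are shown below. What is called first, only, known or untested is meant among the compounds shown, and "the series" means these compounds.

In a functional assay on HT-29 cells (Homo sapiens) for inhibition, read by luminescence and CellTiter-Glo, with a stated time of 24 h (on this read-out lower numbers stand for an effect already at smaller amounts and higher numbers for an effect only at larger amounts of compound), compound 1 `CN1C(=S)[C@@H](NC(=O)c2nc(Cc3ccccc3)n(C)n2)COc2ccccc21` gives 2.5 nM, and compound 2 `CN1C(=S)[C@@H](NC(=O)c2nc(Cc3ccccc3)n(CCC(F)(F)F)n2)COc2ccccc21` gives 1550 nM, the higher of the two numbers. Compound 3 `CN1C(=S)[C@@H](NC(=O)c2nc(Cc3ccccc3)n(CCCCC#N)n2)COc2ccccc21` differs from compound 2 as follows: 2-cyanoethyl in place of trifluoromethyl on a saturated chain carbon, two bonds along the chain from an aromatic nitrogen, which puts 2-cyanoethyl in place of trifluoromethyl on a saturated chain carbon, two bonds along the chain from an aromatic nitrogen. Within the data shown here, only one measured step bears on this change, and it is large: a 620-fold higher number from compound 1 to compound 2 (2.79 log units; beyond the scatter). Compound 3 keeps a long chain there, 4-cyanobutyl, as compound 2 keeps 3,3,3-trifluoropropyl, so no large step in either direction is expected. The estimated step is a 1.7-fold lower number from compound 2 to compound 3 (0.24 log units; within the scatter). For compound 3 the expected value is 900 nM, with an estimated range of 120 nM to 6000 nM.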

Compound 3, half-maximal effective concentration: 2680 nM
Compound 3: middle estimate off by 3.0-fold (0.47 log units), on the low side; the range from low to high includes it.
By their numbers in this assay, from the lowest: compound 1; then compounds 2 and 3 (each within the scatter of the next).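

In this assay, the step of a 1.7-fold higher number from compound 2 to compound 3 (0.24 log units; within the scatter) lies within the scatter, so at this position a chain ending in nitrile and a chain ending in trifluoromethyl read alike. The step of a 1100-fold higher number from compound 1 to compound 3 (3.03 log units; beyond the scatter) is large, so the high number of compound 2 is not confined to trifluoromethyl: both longer chains stand far from the methyl of compound 1. No measurement here explains this. An ethyl or propyl chain with no end group would help show how much chain this position accepts. A chain ending in an amine or a carboxylic acid remains an open case.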